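The compounds below may be only part of what the source reports. "The series", "measured", "known", "first", "only" and "open" are said of these compounds alone.

Working notes on the series. In an ADME assay on cells (Epithelial cell, Homo sapiens) for antiproliferative activity, read by MTT assay, with a stated time of 48 h (on this read-out lower numbers stand for stronger inhibition and higher numbers for weaker inhibition), compound 1 `COC(=O)/C(=C/c1ccccc1)CN1C(=O)[C@@H](OC)[C@H]1c1ccc(Cl)cc1` gives 37900 nM and compound 3 `COC(=O)/C(=C/c1ccccc1)CN1C(=O)[C@@H](OC)[C@H]1c1ccc(Cl)cc1Cl` gives 70000 nM as its reading. Compound 2 `CCOC(=O)/C(=C/c1ccccc1)CN1C(=O)[C@@H](OC)[C@H]1c1ccc(Cl)cc1` is recorded as "not toxic" (no number reported) with no single number, so it has no place on the scale. Compound 4 `CCOC(=O)/C(=C/c1ccccc1)CN1C(=O)[C@@H](OC)[C@H]1c1ccc(F)cc1` differs from compound 2 by fluoro in place of chloro on an aromatic carbon in a change of 4-chlorophenyl to 4-fluorophenyl. Within the data shown here, only one measured step bears on this, a 1.8-fold higher number from compound 1 to compound 3 (0.27 log units; within the scatter) for chloro in place of hydrogen on an aromatic carbon, and it is a different exchange. In this assay no step beyond the scatter is therefore expected, although compound 2 offers no number to start from. The estimate for compound 4 is 60000 nM with an expected range from 25000 nM to 150000 nM in this read-out.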

Compound 4, half-maximal inhibitory concentration: "not toxic" (no number reported)
Nothing numeric was reported for compound 4; no gap can be computed for the estimate.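

Compound 2 and compound 4 are both recorded as "not toxic" without a number in this assay, so no step can be read between them. The compounds shown leave open how the change from 4-chlorophenyl to 4-fluorophenyl shifts the reading, and no supporting data bear on it.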